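Trading a dimethoxyphenyl ketone for a methylphenyl ketone

This account rests on a few compounds, and the source may have more. Where it says the series, first, only, none or still open, it means among the compounds named here.

Measured compounds:
compound 1 `COC(=O)c1cc(-c2cccc(NC(=O)c3ccc(/C=C/C(=O)c4ccc(OC)cc4OC)cc3)c2)on1`: > 50 ug/mL
compound 2 `COC(=O)c1cc(-c2cccc(NC(=O)c3ccc(/C=C/C(=O)c4ccccc4O)cc3)c2)on1`: "not determined" (no result reported)

In an ADME assay on Vero cells (Chlorocebus sabaeus) for cytotoxicity, read by MTT assay, with a stated time of 72 h (on this read-out higher numbers stand for lower toxicity in this test and lower numbers for higher toxicity in this test), compound 1 gives > 50 ug/mL, and this is a limit of the assay rather than a number. In this assay compound 2 gives "not determined" (no result reported), so no result stands against it. Among the values shown, compound 1 therefore sits at the limit of > 50 ug/mL in this assay, at which 1 of the 2 values shown sits, and nothing else has a single number to compare with it.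

Compound 3 `COC(=O)c1cc(-c2cccc(NC(=O)c3ccc(/C=C/C(=O)c4ccc(C)cc4)cc3)c2)on1` differs from compound 1 in one place: 4-methylphenyl in place of 2,4-dimethoxyphenyl on a carbonyl carbon. Going by the values given here, no step between measured compounds is known for this pair, and nothing measured here tells what the change does in this assay. The expectation for compound 3 is a step of a number no higher from compound 1 to compound 3 (the limit leaves the size open) that stays within the usual scatter, with a fair chance that this assay again returns only a limit. Compound 3 is therefore estimated at 50 ug/mL, with a range from 25 ug/mL to 100 ug/mL.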

Compound 3, half-maximal cytotoxic concentration: > 80 ug/mL
Compound 3: only a limit was reported; the forecaster's own chance of this, stated with the estimate: 65%; at least 1.6-fold (0.20 log units) between middle value and limit.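

In this assay compound 3 gives > 80 ug/mL, which is a limit. Compound 1 likewise gives only a limit, > 50 ug/mL. No step can be read between compound 1 and compound 3. The compounds shown leave open what 4-methylphenyl in place of 2,4-dimethoxyphenyl on a carbonyl carbon does in this assay.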